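The source may hold more compounds than are shown below. What is called first, only, known or untested is meant among the compounds shown, and "the series" means these compounds.

Measured compounds:
- compound 1, `N#C/C(=C\c1c[nH]c2ccccc12)C(=O)c1c[nH]c2ccccc12`: 11000 nM
- compound 2, `COc1ccc(CNC(=O)/C(C#N)=C/c2ccc(C)o2)cc1`: 21000 nM

Both values come from a functional assay on MCF7 cells (Homo sapiens) for inhibition, read by MTT assay, with a stated time of 72 h; a higher number here means a weaker inhibitor of growth, a lower number a stronger inhibitor of growth. Compound 1, an acrylonitrile carrying two indole units, gives 11000 nM in this assay. Compound 2, an acrylamide built on a methoxybenzyl amide with the 5-methylfuran-2-yl group on the alkene, gives 21000 nM. Taken together the two numbers are close: the gap between them lies within the usual scatter of repeated measurements, so neither compound can be called the stronger or weaker inhibitor of growth on these data. Compound 2 is the only one that shares its amide scaffold with the compound that follows, so it is the reference point here.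

Compound 3, `COc1ccc(CNC(=O)/C(C#N)=C/c2ccc(C)cc2)cc1`, has not been measured. It differs from compound 2 in one place: 4-methylphenyl in place of 5-methylfuran-2-yl on a double-bonded chain carbon bound to a double-bonded chain carbon. One aromatic ring is exchanged for another on the same carbon of the double bond, with the rest of the molecule unchanged. Among the measured compounds shown here, no measured pair in this set shows the effect of such an exchange, so there is no step to lean on. The expectation is no step beyond the scatter in this assay, in either direction.

On that basis compound 3 is estimated at 20000 nM, with a range from 7000 nM to 60000 nM. The expected step from compound 2 to compound 3 is a 1.1-fold lower number from compound 2 to compound 3 (0.02 log units; within the scatter).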

Compound 3, concentration for 50% growth inhibition: 36000 nM
The estimate for compound 3 lay 1.8-fold (0.26 log units) below the measured number, and the stated range covers the measured number.
By their numbers in this assay, from the lowest: compounds 1, 2 and 3 (each within the scatter of the next, the first and the last beyond it).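

In this assay, among the compounds shown here, the exchange of 5-methylfuran-2-yl for 4-methylphenyl on a double-bonded chain carbon bound to a double-bonded chain carbon gives a 1.7-fold higher number from compound 2 to compound 3 (0.23 log units; within the scatter) and is the first readable step at this position. This position therefore accepts a six-membered aromatic ring of carbon only in place of a five-membered aromatic ring with 1 hetero atom, with no step beyond the scatter, so the ring oxygen and the hydrogen-bond acceptor counted with it are not shown to matter on this single pair. Nothing at hand offers an explanation for how the two rings compare.

As far as these compounds go, both rings carry a methyl group, so it remains open how the series responds when that methyl is replaced by an amine, a carboxylic acid or a longer chain such as propyl on either ring. Also open, from the compounds shown here alone, is whether a ring with a different hetero atom, such as thiophene or pyridine, gives a step beyond the scatter at this position, and whether the same holds with the methoxybenzyl amide changed.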